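Removing a methoxy group from a bis-benzylidene cyclohexanone

The source may hold more compounds than are shown below. What is called first, only, known or untested is meant among the compounds shown, and "the series" means these compounds.

Of the compounds shown here, two of a shared core have been measured. Compound 1 `COc1ccc(/C=C2\CCC/C(=C\c3ccccc3[N+](=O)[O-])C2=O)cc1` carries a methoxy group on one of its two aromatic rings and a nitro group on the other; in a functional assay on MOLT-4 cells (Homo sapiens) for cytotoxicity, with a stated time of 72 h (on this read-out higher numbers stand for weaker inhibition and lower numbers for stronger inhibition), compound 1 gives 8900 nM. Compound 2 `O=C1/C(=C/c2ccc(F)cc2)CCC/C1=C\c1cccc([N+](=O)[O-])c1` places a fluorine and a nitro group on its rings differently; in this assay compound 2 gives 5120 nM. These two values lie within the usual scatter of each other, so neither compound can be called more or less potent than the other.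

Compound 3 `O=C1/C(=C/c2ccccc2)CCC/C1=C\c1ccccc1[N+](=O)[O-]` is compound 1 with a hydrogen in place of methoxy on an aromatic carbon. Among the compounds with values here, no measured pair shows what such a change does here, so the step from compound 1 is expected to stay within the scatter, a 1.0-fold higher number from compound 1 to compound 3 (0.00 log units; within the scatter). Compound 3 is therefore expected to give about 9000 nM, most likely between 3500 nM and 25000 nM.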

Compound 3, half-maximal inhibitory concentration: 1480 nM
The estimate for compound 3 lay 6.1-fold (0.78 log units) above the measured number; the whole stated range lies above it.
By their numbers in this assay, from the lowest: compound 3; then compounds 2 and 1 (each within the scatter of the next).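

Removing the methoxy group, which turns the 4-methoxyphenyl into a plain phenyl, has a real effect in this assay: the result is a 6.0-fold lower number from compound 1 to compound 3 (0.78 log units; beyond the scatter). Until now, the two measured compounds differed in more than one place and lay within the scatter of each other, so they said nothing about this single position. This pair shows that the position, para to a large group, is not indifferent to what it carries, though no measurement shown here explains the change.

This is one pair with one replacement, so it cannot say whether a hydroxyl group, an amine or an ethoxy group in the same place would behave like hydrogen or like methoxy. Nor can it say whether removing the methoxy group would have a similar effect with the nitro group elsewhere on the other ring.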